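From Methyl to Carbamoyl in Compound 3

This account rests on a few compounds, and the source may have more. Where it says the series, first, only, none or still open, it means among the compounds named here.

In a functional assay (aorta) with Rattus norvegicus as the target, in the presence of a further agent that is not named here (on this read-out lower numbers stand for an effect already at smaller amounts and higher numbers for an effect only at larger amounts of compound), compound 1 `COC(=O)C1=C(C)N=C(C)/C(=C(/O)OC)C1c1cccc(OCc2c(C)no[n+]2[O-])c1` gives 400 nM as its reading and compound 2 `COC(=O)C1=C(C)N=C(C)/C(=C(/O)OC)C1c1cccc(OCc2no[n+]([O-])c2C)c1` gives 500 nM as its reading, so compound 2 stands level with compound 1 within the scatter. Compound 3 `COC(=O)C1=C(C)N=C(C)/C(=C(/O)OC)C1c1cccc(OCc2no[n+]([O-])c2C(N)=O)c1` differs from compound 2 by carbamoyl in place of methyl on an aromatic carbon with carbamoyl in place of methyl on an aromatic carbon. Among the measured compounds shown here, the only measured step is a 1.3-fold higher number from compound 1 to compound 2 (0.10 log units; within the scatter) for an exchange of two groups of equal count, and it does not test carbamoyl. No step beyond the scatter is therefore expected in this assay on this thin evidence, and the expected size is a 1.3-fold lower number from compound 2 to compound 3 (0.10 log units; within the scatter) in this estimate. For compound 3 the estimated value is 400 nM within a range of 120 nM to 1300 nM for repeated measurements.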

Compound 3, half-maximal effective concentration: 710 nM
The estimate for compound 3 lay 1.8-fold (0.25 log units) below the measured number, within the range that was stated.
By their numbers in this assay, from the lowest: compounds 1, 2 and 3 (each within the scatter of the next).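

In this assay, carbamoyl in place of methyl on this aromatic carbon gives a 1.4-fold higher number from compound 2 to compound 3 (0.15 log units; within the scatter), so this position takes the larger group, with its hydrogen-bond donor, without a step beyond the scatter. The exchange of the whole group on the saturated chain carbon gives a 1.8-fold higher number from compound 1 to compound 3 (0.25 log units; within the scatter), and compound 3 therefore stands level with compound 1 as well. Nothing available explains these readings. From the compounds shown here alone, whether an amine, a carboxylic acid or a longer chain on this aromatic carbon would produce a step beyond the scatter remains open.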